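Allyloxy to propargyloxy on the shared core

This account rests on a few compounds, and the source may have more. Where it says the series, first, only, none or still open, it means among the compounds named here.

In a functional assay on the whole organism (strain NMRI) with Mus musculus as the target, in the maximal electroshock model, with a stated time of 30 min (on this read-out lower numbers stand for an effect already at smaller amounts and higher numbers for an effect only at larger amounts of compound), compound 1 (`C=CCOCC(N)C(=O)NCc1ccccc1`) gives 45 mg/kg as its dose. Compound 2 (`CCCC[C@@H](N)C(=O)NCc1ccccc1`) stands at 23 mg/kg and compound 3 (`N[C@@H](C(=O)NCc1ccccc1)C1CCCCC1`) at 28 mg/kg on the same read-out. All three values lie within the scatter of one another, so compound 1 is not separated from either.

The change to compound 4 (`C#CCOCC(N)C(=O)NCc1ccccc1`) reads ethynyl in place of vinyl on a saturated chain carbon bound to an oxygen on a saturated carbon and amounts to ethynyl in place of vinyl on a saturated chain carbon bound to an oxygen on a saturated carbon.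

Among the measured compounds shown here, no measured step covers this change. For the measured compounds named here, the only step available, a 1.2-fold higher number from compound 2 to compound 3 (0.09 log units; within the scatter), sits at a different place and offers indirect guidance at best. With compound 1 at 45 mg/kg as the anchor, no shift beyond the scatter is expected in this assay here. The expected move is a 1.1-fold lower number from compound 1 to compound 4 (0.05 log units; within the scatter) and it stays inside the scatter. For compound 4 the estimate is 40 mg/kg with an expected range from 20 mg/kg to 80 mg/kg on this read-out.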

Compound 4, dose for half-maximal effect: 46 mg/kg
For compound 4 the middle estimate is 1.2-fold (0.06 log units) below the measured one; low and high end bracket the measured number.
By their numbers in this assay, from the lowest: compounds 2, 3, 1 and 4 (each within the scatter of the next).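

In this assay, ethynyl in place of vinyl on a saturated chain carbon bound to an oxygen on a saturated carbon gives a 1.0-fold higher number from compound 1 to compound 4 (0.01 log units; within the scatter), the only measured step at this place among the compounds shown. Replacing the double bond with a triple bond, with the same heavy-atom count in the group that leaves and the group that enters, therefore leaves the read-out within the scatter, something a 1.2-fold higher number from compound 2 to compound 3 (0.09 log units; within the scatter) could not show from its different place. No other measurement bears on this result.

Still open, as far as these compounds go, is whether allyloxy and propargyloxy are matched only with each other or whether other groups at this place, such as methoxy, a longer chain ether or benzyloxy, also stay within the scatter. A free hydroxyl or an amine there would test the same question with a group that carries hydrogen-bond donors.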